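The source may hold more compounds than are shown below. What is called first, only, known or untested is meant among the compounds shown, and "the series" means these compounds.

In a functional assay on JAR cells (Homo sapiens) for inhibition, read by MTT assay, with a stated time of 72 h, tested at 10 uM (a lower number here means less inhibition, a higher number more inhibition at the concentration tested (going by the name of the read-out)), the measured compounds give:
compound 1 `CCOC(=O)C1=C(Nc2ccccc2)S/C(=C\c2ccc(O)c(O)c2)C1=O`: 48.7%
compound 2 `CCOC(=O)C1=C(Nc2ccccc2)S/C(=C\c2ccc(OC)cc2)C1=O`: 32.9%
compound 3 `CCOC(=O)C1=C(Nc2ccccc2)S/C(=C\c2ccc(Br)c(O)c2)C1=O`: 39.8%

Compound 3 stands second highest of the three numbers in this assay, within the scatter of both compound 2 below it and compound 1 above it. Compound 4 `CCOC(=O)C1=C(Nc2ccccc2)S/C(=C\c2ccccc2O)C1=O` is reached from compound 3 by one change: 2-hydroxyphenyl in place of 4-bromo-3-hydroxyphenyl on a double-bonded chain carbon bound to a double-bonded ring carbon. Bearing on this are the two earlier swaps of the aryl group at the same place, a number 15.8 percentage points lower from compound 1 to compound 2 (beyond the scatter) and a number 6.9 percentage points higher from compound 2 to compound 3 (within the scatter), and the single substituent step a number 8.9 percentage points lower from compound 1 to compound 3 (within the scatter); none moved the number by more than a modest amount, and the donor and acceptor counts are unchanged in the present swap. A step of a number 3.8 percentage points lower from compound 3 to compound 4 (within the scatter) is therefore expected, within the scatter. Compound 4 is estimated at 36%, range 22% to 50%.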

Compound 4, a percentage reported as inhibition, at one concentration (the size of the read-out at that concentration, not a potency): 89.4%
Compound 4: the middle estimate sits 53.4 percentage points below what was measured; the whole stated range lies below it.
By their numbers in this assay, from the lowest: compounds 2, 3 and 1 (each within the scatter of the next, the first and the last beyond it); then compound 4.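

At the double-bonded chain carbon bound to a double-bonded ring carbon, the aryl group can move the number far more than the earlier swaps showed: in this assay, 2-hydroxyphenyl gives a number 49.6 percentage points higher from compound 3 to compound 4 (beyond the scatter) and a number 56.5 percentage points higher from compound 2 to compound 4 (beyond the scatter) and a number 40.7 percentage points higher from compound 1 to compound 4 (beyond the scatter). Between 4-bromo-3-hydroxyphenyl and 2-hydroxyphenyl the donor and acceptor counts stay the same, so these counts do not track this step. No measurement shown here accounts for the jump.

Open, as far as these compounds go, is whether the gain depends on the hydroxy group of 2-hydroxyphenyl itself. Unsubstituted phenyl, 2-methoxyphenyl or 2-aminophenyl at this place would test that.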